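The source may report more compounds than this note shows. Statements on the series, on what has been measured and on what is new or still open speak of the compounds shown alone.

In a physicochemical assay for solubility, in phosphate buffer, measured as kinetic solubility, at pH 7.4, tested at 250 uM (a higher number here means a more soluble compound, a lower number a less soluble compound), compound 1 (`CCCCCCNc1ccc(C(=O)O)cc1S(=O)(=O)N(C)C`) gives 243000 nM. Compound 2 (`CN(C)S(=O)(=O)c1cc(C(=O)O)ccc1NCCC(C)(C)C`) reads > 250000 nM, which is a limit of the assay and not a number, and it is recorded as the limit of > 250000 nM in this assay, at which 1 of the 2 values shown sits. Compound 3 (`CN(C)S(=O)(=O)c1cc(C(=O)O)ccc1NCCCCCC(F)(F)F`) carries 4,4,4-trifluorobutyl in place of tert-butyl on a saturated chain carbon, two bonds along the chain from a nitrogen on an aromatic ring. Going by the values given here, only one measured step bears on this place, an at least 1.0-fold higher number from compound 1 to compound 2 (0.01 log units; that floor lies within the scatter), and it gives no sign of a large effect from changing this chain. No step beyond the scatter is therefore expected in this assay. The expected change is an at least 1.1-fold lower number from compound 2 to compound 3 (0.05 log units; that floor lies within the scatter). Compound 3 is estimated at 220000 nM, with an expected range of 120000 nM to 260000 nM.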

Compound 3, solubility: 249000 nM
Compound 3: the middle estimate sits 1.1-fold (0.05 log units) below what was measured; measured number inside the range.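

In this assay, trifluoromethyl in place of methyl on a saturated chain carbon, five bonds along the chain from a nitrogen on an aromatic ring, gives a 1.0-fold higher number from compound 1 to compound 3 (0.01 log units; within the scatter). Unlike the earlier step on this chain, this one rests on two readable numbers, and it shows that these two chain ends give values within the scatter of each other. 4,4,4-trifluorobutyl in place of tert-butyl on a saturated chain carbon, two bonds along the chain from a nitrogen on an aromatic ring, gives a number no higher from compound 2 to compound 3 (the limit leaves the size open). The size of this step cannot be read, because compound 2 stands at a limit of the assay and not at a number: the limit of > 250000 nM in this assay, at which 1 of the 3 values shown sits.

The compounds shown all carry plain or fluorinated saturated chains, so they say nothing about a chain bearing an amine or a hydroxyl group. Going by these compounds, whether a cyclohexyl group at this position would move the reading beyond the scatter also stays open.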